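Cyclohexyl to cyclopentyl on the piperidine benzyl position

A few compounds are considered here, and "the series" means these few. Any claim that something is new, unique, unknown or untested is made for them only; others in the source may bear on it.

Measured so far:
compound 1 `O=C(CCC1CCN(Cc2ccccc2)CC1)c1ccc2[nH]ccc2c1` — 169 nM
compound 2 `O=C(CCC1CCN(CC2CCCCC2)CC1)c1ccc2[nH]ccc2c1` — 37.5 nM

For the measured compounds named here, compound 2 `O=C(CCC1CCN(CC2CCCCC2)CC1)c1ccc2[nH]ccc2c1` holds the lower of the two numbers in an assay for displacement of a labelled ligand from 5-hydroxytryptamine receptor 4 (Homo sapiens), with a stated time of 60 min; a lower number here means a stronger inhibitor, a higher number a weaker inhibitor; its nearest neighbour is compound 1 `O=C(CCC1CCN(Cc2ccccc2)CC1)c1ccc2[nH]ccc2c1`, and the one step between them, a 4.5-fold lower number from compound 1 to compound 2 (0.65 log units; beyond the scatter), lies beyond the scatter. That step exchanged a six-membered aromatic ring for a six-membered saturated one of carbon only at the same place.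

Compound 3 `O=C(CCC1CCN(CC2CCCC2)CC1)c1ccc2[nH]ccc2c1` is not yet measured. It differs from compound 2 by cyclopentyl in place of cyclohexyl on a saturated chain carbon bound to an amine nitrogen in a ring. The ring stays saturated and made of carbon only; only the ring size changes, from six-membered to five-membered.

Going by the values given here, no measured step bears directly on this change. The single step shown, from compound 1 to compound 2, concerns aromatic against saturated and says nothing about ring size within a saturated ring. The expectation is therefore a step of no more than the scatter, with no direction that the data support; compound 3 is estimated at 50 nM, within 18 nM to 140 nM, a change of a 1.3-fold higher number from compound 2 to compound 3 (0.12 log units; within the scatter) from compound 2.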

Compound 3, inhibition constant: 25 nM
Compound 3: the middle estimate sits 2.0-fold (0.30 log units) above what was measured; measured number inside the range.
By their numbers in this assay, from the lowest: compounds 3 and 2 (each within the scatter of the next); then compound 1.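

In this assay, the saturated carbon ring on a saturated chain carbon bound to an amine nitrogen in a ring can now be read for ring size, and cyclopentyl and cyclohexyl cannot be told apart here (a 1.5-fold lower number from compound 2 to compound 3 (0.18 log units; within the scatter)). The gain over phenyl is therefore not tied to the six-membered saturated ring: the five-membered one also stands clear of compound 1 (a 6.8-fold lower number from compound 1 to compound 3 (0.83 log units; beyond the scatter)), so among these compounds phenyl alone stands apart and neither compound 2 nor compound 3 goes against this. Nothing measured alongside these numbers accounts for this reading of the position.

Still open, from the compounds shown here alone, is how far the ring can shrink or change in kind at this place, with cyclobutyl, cyclopropyl, tetrahydropyranyl or an open isobutyl group as the obvious next groups to test, and whether a longer chain between the ring and the amine nitrogen would keep these numbers. Going by these compounds, all three numbers come from this assay alone and how the change from cyclohexyl to cyclopentyl reads at any other receptor remains unknown.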